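Cyclopentylmethyl Urea on an Aryl Sulfonate Scaffold

The compounds below may be only part of what the source reports. "The series", "measured", "known", "first", "only" and "open" are said of these compounds alone.

compound 1 `CC(=O)Nc1ccc(S(=O)(=O)Oc2ccccc2C(C)C)cc1`: 12000 nM
compound 2 `CC(C)c1ccccc1OS(=O)(=O)c1ccc(NC(=O)C(C)(C)C)cc1`: 11000 nM
compound 3 `CCNC(=O)Nc1ccc(S(=O)(=O)Oc2ccccc2C(C)C)cc1`: 250 nM

In a functional assay on HT-1080 cells (Homo sapiens) for antiproliferative activity, read by sulforhodamine B assay, with a stated time of 48 h (a higher number here means a weaker inhibitor, a lower number a stronger inhibitor), compound 3 gives 250 nM, the lowest of the three numbers; compound 1 gives 12000 nM and compound 2 gives 11000 nM. The steps of a 48-fold lower number from compound 1 to compound 3 (1.68 log units; beyond the scatter) and a 44-fold lower number from compound 2 to compound 3 (1.64 log units; beyond the scatter) are large, whereas a 1.1-fold lower number from compound 1 to compound 2 (0.04 log units; within the scatter) is small; all three alter the group on the carbonyl carbon, which compound 4 keeps. Compound 4 `CC(C)c1ccccc1OS(=O)(=O)c1ccc(NC(=O)NCC2CCCC2)cc1` differs from compound 3 by cyclopentyl in place of methyl on a saturated chain carbon bound to an amide-type nitrogen. Among the measured compounds shown here, no measured step touches that place, so the data give no direct guide. With the urea retained, the expected step is a 1.1-fold lower number from compound 3 to compound 4 (0.06 log units; within the scatter), not beyond the scatter. Compound 4 is therefore estimated at 220 nM, between 60 nM and 800 nM.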

Compound 4, half-maximal inhibitory concentration: 6000 nM
The estimate for compound 4 lay 27-fold (1.44 log units) below the measured number, and the stated range ends below it.
By their numbers in this assay, from the lowest: compound 3; then compounds 4, 2 and 1 (each within the scatter of the next).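

In this assay, cyclopentyl in place of methyl on a saturated chain carbon bound to an amide-type nitrogen gives a 24-fold higher number from compound 3 to compound 4 (1.38 log units; beyond the scatter), so keeping the urea does not by itself keep the low number. The steps of a 1.8-fold lower number from compound 2 to compound 4 (0.26 log units; within the scatter) and a 2.0-fold lower number from compound 1 to compound 4 (0.30 log units; within the scatter) lie within the scatter, leaving (cyclopentylmethyl)amino level with tert-butyl and methyl on a carbonyl carbon. Nothing available explains this loss. Left open is whether propyl or cyclopropylmethyl in place of ethyl would keep the number of compound 3 or follow compound 4.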